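A few compounds are considered here, and "the series" means these few. Any claim that something is new, unique, unknown or untested is made for them only; others in the source may bear on it.

Measured so far in a functional assay on HepG2 cells (Homo sapiens) for antiproliferative activity, read by MTT assay; on this read-out higher numbers stand for weaker inhibition and lower numbers for stronger inhibition:

compound 1, `CNC(=O)c1ccc(Oc2cccc(NC(=S)Nc3ccc(F)cc3)c2)nc1`: 42500 nM
compound 2, `CNC(=O)c1ccc(Oc2cccc(NC(=S)Nc3ccc(Cl)cc3Cl)c2)nc1`: 21600 nM
compound 3, `CNC(=O)c1ccc(Oc2cccc(NC(=S)Nc3ccc(F)c(F)c3)c2)nc1`: 26700 nM

All three compounds share one core and differ only in the aryl group on the thiourea nitrogen. Compound 3 sits between the other two, and both of its gaps are within the scatter: a 1.2-fold higher number from compound 2 to compound 3 (0.09 log units; within the scatter) and a 1.6-fold lower number from compound 1 to compound 3 (0.20 log units; within the scatter). The remaining pair behaves the same way, with a 2.0-fold lower number from compound 1 to compound 2 (0.29 log units; within the scatter). Across these three halogenated aryl groups, then, this assay shows no movement beyond the scatter.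

Compound 4, `CNC(=O)c1ccc(Oc2cccc(NC(=S)Nc3ccc(OC)cc3)c2)nc1`, has not yet been measured. It differs from compound 3 as follows: 4-methoxyphenyl in place of 3,4-difluorophenyl on an amide-type nitrogen. Within the data shown here, no measured step covers this particular exchange; the three measured steps only swap one halogen pattern for another and all stayed within the scatter. Those steps are the nearest guide, and they give no reason to expect a shift beyond the scatter for compound 4 either, though an aryl group without halogen is new ground here and widens the uncertainty.

On that basis compound 4 is expected to give about 30000 nM in this assay, with a plausible range from 12000 nM to 75000 nM. The expected step is a 1.1-fold higher number from compound 3 to compound 4 (0.05 log units; within the scatter).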

Compound 4, half-maximal inhibitory concentration: 85300 nM
For compound 4 the middle estimate is 2.8-fold (0.45 log units) below the measured one; measured number outside the range, above it.
By their numbers in this assay, from the lowest: compounds 2, 3, 1 and 4 (each within the scatter of the next, the first and the last beyond it).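

With the halogen patterns alone, this position showed no movement beyond the scatter, but the amide-type nitrogen does respond to a change of aryl group in this assay: 4-methoxyphenyl in place of 3,4-difluorophenyl gives a 3.2-fold higher number from compound 3 to compound 4 (0.50 log units; beyond the scatter), and in place of 2,4-dichlorophenyl it gives a 3.9-fold higher number from compound 2 to compound 4 (0.60 log units; beyond the scatter), both modest steps towards weaker inhibition. The change is not equally visible from every halogenated partner, however: methoxy in place of fluoro gives only a 2.0-fold higher number from compound 1 to compound 4 (0.30 log units; within the scatter), so the two steps beyond the scatter start from compound 2 and compound 3, the two compounds with two halogens on the ring, while compound 1, with one, goes against any general loss on replacing halogen. Nothing among the available data accounts for this difference in the steps.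

The compounds shown leave open whether the shift belongs to the methoxy group itself or simply to an aryl group without halogen, a question that an unsubstituted phenyl or a 4-methylphenyl at this position would address. They also leave open how this position would respond to a 4-aminophenyl, a 4-carboxyphenyl or a longer chain such as 4-ethoxyphenyl.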